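A Saturated Ring Added to Compound 1

The source may hold more compounds than are shown below. What is called first, only, known or untested is meant among the compounds shown, and "the series" means these compounds.

Within the data shown here, in an in vitro ADME assay on microsomes from liver (Homo sapiens) for metabolic stability (on this read-out lower numbers stand for slow clearance and higher numbers for fast clearance), compound 1 `CC(C)Nc1nccc(-c2cn[nH]c2)n1` gives 0.021 mL/min/kg, the only exact number available so far. Compound 2 `C[C@H](CC(=O)O)Nc1nccc(-c2c[nH]nc2-c2ccc(Cl)cc2)n1` is reported only as a limit of the assay, < 0.006 mL/min/kg. Compound 3 `CC(C)Nc1nccc(-c2c[nH]nc2C2CCCOC2)n1` has oxan-3-yl in place of hydrogen on an aromatic carbon of the core of compound 1: oxan-3-yl in place of hydrogen on an aromatic carbon. Among the measured compounds shown here, no measured step covers this kind of change, so only a small rise in this assay is expected, within the scatter: a 1.4-fold higher number from compound 1 to compound 3 (0.15 log units; within the scatter). Compound 3 is estimated at 0.03 mL/min/kg, with an expected range of 0.012 mL/min/kg to 0.07 mL/min/kg.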

Compound 3, clearance: 0.034 mL/min/kg
Compound 3: middle estimate off by 1.1-fold (0.05 log units), on the low side; low and high end bracket the measured number.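

On the aromatic carbon of the five-membered ring, oxan-3-yl in place of hydrogen is tolerated in this assay: the step is a 1.6-fold higher number from compound 1 to compound 3 (0.21 log units; within the scatter) and so gives no readable difference between the two compounds. This shows that a six-membered non-aromatic ring can sit at this position without a difference beyond the scatter. Only compound 2 is reported as a limit of the assay: the limit of < 0.006 mL/min/kg in this assay, at which 1 of the 3 values shown sits. As far as these compounds go, it remains open whether a piperidine ring, with a nitrogen in place of the ring oxygen, or an open butyl chain at this position would give the same result.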